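Swapping a halogenated ring for a dimethoxy ring

This account rests on a few compounds, and the source may have more. Where it says the series, first, only, none or still open, it means among the compounds named here.

Compound 1 `COc1cc2ncnc(Nc3ccc(F)c(Cl)c3)c2cc1NC(=O)/C=C/c1ccc(F)cc1Cl` and compound 2 `N#Cc1ccc(/C=C/C(=O)Nc2cc3c(Nc4ccc(F)c(Cl)c4)ncnc3cc2O[C@H]2CCOC2)cc1` share a core carrying an amide-linked alkene chain that ends in an aromatic ring. In a functional assay on PC-3 cells (Homo sapiens) for cytotoxicity, read by MTT assay, with a stated time of 72 h (a lower number here means a stronger inhibitor, a higher number a weaker inhibitor), compound 1 gives 32700 nM, and compound 2 gives 36600 nM. These two numbers lie within the usual scatter of repeated measurements of each other, so neither compound can be ranked above the other; both are weak inhibitors in this assay. Compound 3 `COc1ccc(/C=C/C(=O)Nc2cc3c(Nc4ccc(F)c(Cl)c4)ncnc3cc2OC)c(OC)c1` differs from compound 1 in one place: 2,4-dimethoxyphenyl in place of 2-chloro-4-fluorophenyl on a double-bonded chain carbon bound to a double-bonded chain carbon. Among the measured compounds shown here, no measured pair shows the effect of such a change, so there is no measured step to lean on, and the amide chain and shared core stay untouched. The step of a 1.1-fold lower number from compound 1 to compound 3 (0.04 log units; within the scatter) is expected to fall within the scatter, in no clear direction. Compound 3 is estimated at 30000 nM, with a range from 10000 nM to 90000 nM.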

Compound 3, half-maximal inhibitory concentration: 38500 nM
Beside the measured number, compound 3's estimate is 1.3-fold (0.11 log units) below it; the measured number falls inside the stated range.
By their numbers in this assay, from the lowest: compounds 1, 2 and 3 (each within the scatter of the next).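

In this assay, among the compounds shown here, putting 2,4-dimethoxyphenyl in place of 2-chloro-4-fluorophenyl on a double-bonded chain carbon bound to a double-bonded chain carbon gives the first measured step at this position (a 1.2-fold higher number from compound 1 to compound 3 (0.07 log units; within the scatter)). A ring bearing chlorine and fluorine and a ring bearing methoxy groups therefore cannot be told apart in this read-out, so this particular exchange leaves the compound as weak as before. No supporting measurement bears on why the two rings give such similar numbers.

Still open, as far as these compounds go, is whether a different kind of group on this ring, such as an amine or a carboxylic acid, would move the number beyond the scatter. It is also unknown whether a longer chain between the amide and the ring would matter more than the ring's own groups.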